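The source may hold more compounds than are shown below. What is called first, only, known or untested is meant among the compounds shown, and "the series" means these compounds.

Measured compounds in a functional assay on the whole organism (Tail, strain ICR) with Mus musculus as the target, in the tail flick test, with a stated time of 120 min, at a dose of 25 umol/kg by the oral route; on this read-out lower numbers stand for a weaker effect and higher numbers for a stronger effect at the one dose given:

Compound 1, `O=C(CN(c1nc(Cl)nc2[nH]cnc12)C1CC1)N[C@@H](CO)C(=O)OCc1ccccc1`, gives 34.5%.
Compound 2, `C[C@@H](O)[C@H](NC(=O)CN(c1nc(Cl)nc2[nH]cnc12)C1CC1)C(=O)OCc1ccccc1`, gives 30.7%.
Compound 3, `C[C@@H](O)[C@H](NC(=O)CN(c1ncnc2c1ncn2C1CCCCO1)C1CC1)C(=O)OCc1ccccc1`, gives 10.9%.

Compounds 1 and 2 share one core, and compound 3 carries a different one; the difference between the two cores is not broken down here. Within the shared core, compound 2 and compound 1 are related by a single change, (hydrogen in place of methyl on a saturated chain carbon bound to an oxygen on a saturated carbon and a saturated chain carbon), and in this assay that change made a step of a number 3.8 percentage points higher from compound 2 to compound 1 (within the scatter). Compound 3 stands lowest of the three measured compounds, with compound 2 nearer to it and compound 1 further away, both gaps lying beyond the scatter.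

Compound 4, `O=C(CN(c1ncnc2c1ncn2C1CCCCO1)C1CC1)N[C@@H](CO)C(=O)OCc1ccccc1`, has not been measured. It differs from compound 3 by hydrogen in place of methyl on a saturated chain carbon bound to an oxygen on a saturated carbon and a saturated chain carbon. Among the compounds with values here, this is the same change as the one from compound 2 to compound 1, made at a place described in the same words, but now on the core of compound 3 instead of the shared core of compounds 1 and 2.

The step from compound 3 to compound 4 in this assay is expected to be small, about a number 3.1 percentage points higher from compound 3 to compound 4 (within the scatter), because the same change earlier gave a number 3.8 percentage points higher from compound 2 to compound 1 (within the scatter) and stayed within the scatter. Within the data shown here, compound 4 is therefore estimated at 14%, with a range from 3% to 28%, since the starting point of compound 3, 10.9%, is low and only one earlier example of this change is available to lean on.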

Compound 4, a percentage reported as activity, at one dose (the size of the read-out at that dose, not a potency): 29.2%
Beside the measured number, compound 4's estimate is 15.2 percentage points below it; measured number outside the range, above it.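

In this assay, within the data shown here, exchanging 1-hydroxyethyl for hydroxymethyl on the core of compound 3 gave a number 18.3 percentage points higher from compound 3 to compound 4 (beyond the scatter), a step of a different size from the one the same change gave on the shared core. The size of this step therefore did not carry over from one core to the other: the same change on two cores in this assay, a number 3.8 percentage points higher (within the scatter) from compound 2 to compound 1 and a number 18.3 percentage points higher (beyond the scatter) from compound 3 to compound 4, 14.5 percentage points apart, beyond the scatter of two such steps The numbers rise on both cores, but the earlier step lies within the scatter, and two steps do not establish a common direction, show which part of the difference between the cores goes with the larger step, or predict the size of the step on any further core.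

The compounds shown leave open how far the result rests on the hydroxyl itself, as an aminomethyl group, a plain methyl group or a longer chain in place of hydroxymethyl would test on both cores. They also leave open whether the gap between the two steps would persist at other doses or times, given that this assay reports the effect at a single dose and a single time.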